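The source may hold more compounds than are shown below. What is called first, only, known or untested is meant among the compounds shown, and "the series" means these compounds.

Measured so far:
compound 1 `CC(=O)OC[C@H]1O[C@@H](n2cc(CN3C(=O)/C(=C\C=C\c4ccccc4)c4ccccc43)nn2)[C@H](OC(C)=O)[C@@H](OC(C)=O)[C@@H]1OC(C)=O` — 34100 nM
compound 2 `CC(=O)OC[C@H]1O[C@@H](n2cc(CN3C(=O)/C(=C\c4ccc(N(C)C)cc4)c4ccccc43)nn2)[C@H](OC(C)=O)[C@@H](OC(C)=O)[C@@H]1OC(C)=O` — 29800 nM

In a functional assay on MCF7 cells (Homo sapiens) for cytotoxicity, read by sulforhodamine B assay, with a stated time of 48 h (on this read-out higher numbers stand for weaker inhibition and lower numbers for stronger inhibition), compound 1 gives 34100 nM and compound 2 gives 29800 nM. Compound 2 stands at the lowest of these two numbers, but compound 1 is its nearest neighbour and sits within the scatter of it, so the two cannot be told apart. Among the measured compounds shown here, the only measured step, a 1.1-fold lower number from compound 1 to compound 2 (0.06 log units; within the scatter), swapped the group on the double-bonded chain carbon bound to a double-bonded ring carbon and left the read-out where it was.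

Compound 3 `CC(=O)OC[C@H]1O[C@@H](n2cc(CN3C(=O)/C(=C\c4cccs4)c4ccccc43)nn2)[C@H](OC(C)=O)[C@@H](OC(C)=O)[C@@H]1OC(C)=O` differs from compound 2 by thiophen-2-yl in place of 4-(dimethylamino)phenyl on a double-bonded chain carbon bound to a double-bonded ring carbon. For the measured compounds named here, the one step that bears on this place is the step from compound 1 to compound 2, and it stayed within the scatter. Because of a 1.1-fold lower number from compound 1 to compound 2 (0.06 log units; within the scatter), the change to compound 3 is expected to give a step of a 1.2-fold higher number from compound 2 to compound 3 (0.07 log units; within the scatter) in this assay, with no direction beyond the scatter. Compound 3 is therefore estimated at 35000 nM, within a range from 12000 nM to 100000 nM.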

Compound 3, half-maximal inhibitory concentration: 36100 nM
Compound 3: the middle estimate sits 1.0-fold (0.01 log units) below what was measured, and the stated range covers the measured number.
By their numbers in this assay, from the lowest: compounds 2, 1 and 3 (each within the scatter of the next).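

In this assay, a third group on a double-bonded chain carbon bound to a double-bonded ring carbon still gives no separation: replacing 4-(dimethylamino)phenyl with thiophen-2-yl gives a 1.2-fold higher number from compound 2 to compound 3 (0.08 log units; within the scatter), and replacing 2-phenylethenyl with thiophen-2-yl gives a 1.1-fold higher number from compound 1 to compound 3 (0.02 log units; within the scatter). Where the earlier compounds offered a single comparison at this place, there are now three groups, and a five-membered aromatic ring with 1 hetero atom and 5 heavy atoms cannot be told apart from the 4-(dimethylamino)phenyl group, with its six-membered aromatic ring of carbon only and 9 heavy atoms. No measurement is available to explain why these three compounds read alike.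

All three groups shown at this place carry an aromatic ring, so it remains open whether a group without one, such as a carboxylic acid or an amine on a short chain, would move the number beyond the scatter. The acetyl esters are also the same in all three compounds, which leaves open what free hydroxyl groups in their place would do in this assay.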